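Swapping aminoamino for hydroxy on compound 1

This account rests on a few compounds, and the source may have more. Where it says the series, first, only, none or still open, it means among the compounds named here.

Compound 1 `NNC(=O)CCc1ccncc1-c1ccc2ccccc2c1` gives > 10000 nM
Compound 2 `O=C(/C=C/c1ccncc1-c1ccc2cc[nH]c2c1)N1CCOCC1` gives > 10000 nM
Compound 3 `Cn1ccc2cc(-c3cnccc3/C=C/C(=O)O)ccc21` gives > 10000 nM

In a functional assay on KB cells (Homo sapiens) for inhibition, read by sulforhodamine B assay, with a stated time of 72 h (on this read-out lower numbers stand for stronger inhibition of growth and higher numbers for weaker inhibition of growth), compound 1 gives > 10000 nM as its result, and this is a limit of the assay rather than a number. Compound 1 therefore has no exact place on the scale, and it shares that position with both other compounds: the limit of > 10000 nM in this assay, at which 3 of the 3 values shown sit, is all that the data show so far.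

Compound 4 `O=C(O)CCc1ccncc1-c1ccc2ccccc2c1` has not yet been measured. It keeps the core of compound 1 but carries hydroxy in place of aminoamino on a carbonyl carbon and so turns 2-(aminocarbamoyl)ethyl into 2-carboxyethyl.

Compound 3 also ends in a carboxy group, and its > 10000 nM reading is likewise a limit. The expected step that the limit leaves unreadable from compound 1 to compound 4 therefore stays within the scatter in this assay and has no clear direction. A further limit is the most likely report. For compound 4 the estimated value is 15000 nM (expected range 5000 nM to 40000 nM) in this estimate.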

Compound 4, concentration for 50% growth inhibition: > 10000 nM
Compound 4 gave a limit, no number; the forecaster's own chance of this, stated with the estimate: 85%; the middle value is on the limit's open side.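

Among these compounds, compound 4 gives > 10000 nM as a limit of the assay and not a number, so no step from compound 1 to compound 4 can be read. The compounds shown leave open how strongly any of them inhibits growth, with all of them sharing one position: the limit of > 10000 nM in this assay, at which 4 of the 4 values shown sit.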